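The source may hold more compounds than are shown below. What is called first, only, known or untested is meant among the compounds shown, and "the series" means these compounds.

Measured so far in a functional assay on MDA-MB-231 cells (Homo sapiens) for cytotoxicity, read by MTT assay, with a stated time of 72 h, tested at 5 uM, in the absence of a further agent; a lower number here means a stronger effect, a higher number a weaker effect of the compound at the concentration tested:
- compound 1 `CC1(C)CC(NCCCCO)=Nc2ccc(Cl)cc21`: compound 1 gives 84.9%
- compound 2 `CN(C)CCCNC1=Nc2ccc(Cl)cc2C(C)(C)C1`: compound 2 gives 38%
- compound 3 `CN(C)CCNC1=Nc2ccc(Cl)cc2C(C)(C)C1`: compound 3 gives 50.8%

All three share one core and differ only in the side chain attached to the amine nitrogen. Compound 3 stands second highest of the three numbers: its nearest neighbour is compound 2, a number lower by a number 12.8 percentage points higher from compound 2 to compound 3 (beyond the scatter) read in reverse, and its furthest is compound 1, whose number is higher by a number 34.1 percentage points lower from compound 1 to compound 3 (beyond the scatter) read in reverse.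

Compound 4 `CCN(CC)CCCNC1=Nc2ccc(Cl)cc2C(C)(C)C1` is not yet measured. Compared with compound 3 it carries a different side chain: (diethylamino)methyl in place of dimethylamino on a saturated chain carbon, two bonds along the chain from an amine nitrogen

For the measured compounds named here, the step that bears most directly on this change is the one between compound 2 and compound 3, where shortening the chain by one saturated carbon gave a number 12.8 percentage points higher from compound 2 to compound 3 (beyond the scatter), a modest rise. Compound 4 lengthens the chain again by one carbon and in addition swaps the two methyl groups on the terminal nitrogen for two ethyl groups. The larger steps, a number 46.9 percentage points lower from compound 1 to compound 2 (beyond the scatter) and a number 34.1 percentage points lower from compound 1 to compound 3 (beyond the scatter), concern an alcohol being replaced and do not speak to this step. A modest fall of roughly the size of the step of a number 12.8 percentage points higher from compound 2 to compound 3 (beyond the scatter) is therefore expected. Compound 4 is accordingly expected to show a number 12.8 percentage points lower from compound 3 to compound 4 (beyond the scatter), an estimated 38%, within 25% to 52%.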

Compound 4, a percentage reported as activity, at one concentration (the size of the read-out at that concentration, not a potency): 36.1%
For compound 4 the middle estimate is 1.9 percentage points above the measured one; the range from low to high includes it.
By their numbers in this assay, from the lowest: compounds 4 and 2 (each within the scatter of the next); then compound 3; then compound 1.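

In this assay, for the compounds shown here, the earlier compounds did not show what happens when the ends of the chain are enlarged while its length stays fixed: with diethylamino in place of dimethylamino on a saturated chain carbon, three bonds along the chain from an amine nitrogen, the result is a number 1.9 percentage points lower from compound 2 to compound 4 (within the scatter), so the two end groups cannot be told apart here. The step of a number 14.7 percentage points lower from compound 3 to compound 4 (beyond the scatter) is close in size to the step of a number 12.8 percentage points higher from compound 2 to compound 3 (beyond the scatter) read in the opposite direction, so among these compounds the difference goes with chain length rather than with ethyl against methyl on the end nitrogen. The step of a number 48.8 percentage points lower from compound 1 to compound 4 (beyond the scatter) shows that the large gap from the alcohol-ended chain is not confined to dimethylamino, since it also appears with diethylamino.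

No measurement at hand gives a reason for any of these steps. Still open, going by these compounds, is how a ring amine such as piperidine or morpholine at the end of the chain, a primary amine, or a longer chain carrying diethylamino would behave at this position.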